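Series notes: fluoroalkoxy variation on the aryl ether

A few compounds are considered here, and "the series" means these few. Any claim that something is new, unique, unknown or untested is made for them only; others in the source may bear on it.

In an assay on frontal cortex for displacement of a labelled ligand from corticotropin-releasing factor receptor 1 (Rattus norvegicus), with a stated time of 2 h (a lower number here means a stronger inhibitor, a higher number a weaker inhibitor), the measured compounds stand as follows:
compound 1 `COC[C@@H](C)n1cc(Cl)nc(Nc2cc(C)c(OC)cc2C)c1=O` gives 0.88 nM
compound 2 `COCC(COC)n1cc(Cl)nc(Nc2c(Cl)cc(OC)cc2Cl)c1=O` gives 5 nM
compound 3 `COCC(COC)n1cc(Cl)nc(Nc2c(Cl)cc(OCF)cc2Cl)c1=O` gives 5.4 nM

Compound 3 carries the highest number of the three in this assay. Its nearest neighbour is compound 2, and the gap between compound 2 and compound 3 is a 1.1-fold higher number from compound 2 to compound 3 (0.03 log units; within the scatter), so the two cannot be ordered. Compound 1 sits furthest away, with a number beyond the scatter lower than that of compound 3.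

Compound 4 `COCC(COC)n1cc(Cl)nc(Nc2c(Cl)cc(OCCF)cc2Cl)c1=O` differs from compound 3 by fluoromethyl in place of fluoro on a saturated chain carbon bound to an oxygen on an aromatic ring. For the measured compounds named here, the only measured step that touches this part of the molecule is a 1.1-fold higher number from compound 2 to compound 3 (0.03 log units; within the scatter), which put a fluoro onto the same saturated chain carbon without moving the number. Lengthening that chain further has no measured precedent in the set; no pair shows what a fluoromethyl in place of fluoro at this place does. Going by the values given here, on the one relevant step being flat, compound 4 is expected to land close to compound 3 in this assay, with a 1.1-fold higher number from compound 3 to compound 4 (0.05 log units; within the scatter) as the expected step, not beyond the scatter. The estimate for compound 4 is therefore 6 nM, with a range from 2.5 nM to 15 nM to allow for the untested chain extension.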

Compound 4, half-maximal inhibitory concentration in the corticotropin-releasing factor receptor 1 assay: 210 nM
Beside the measured number, compound 4's estimate is 35-fold (1.54 log units) below it, and the stated range ends below it.
By their numbers in the corticotropin-releasing factor receptor 1 assay, from the lowest: compound 1; then compounds 2 and 3 (each within the scatter of the next); then compound 4.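

At this place, on a saturated chain carbon bound to an oxygen on an aromatic ring, the corticotropin-releasing factor receptor 1 assay gives a 1.1-fold higher number from compound 2 to compound 3 (0.03 log units; within the scatter) for the fluoro step alone, but the change from fluoromethoxy to 2-fluoroethoxy is not flat: it gives a 39-fold higher number from compound 3 to compound 4 (1.59 log units; beyond the scatter) and the series loses much of its binding strength at this position. Read against the plain methoxy ether, the same assay, the corticotropin-releasing factor receptor 1 assay, gives a 42-fold higher number from compound 2 to compound 4 (1.62 log units; beyond the scatter), so the position tolerates a fluoro on the existing chain carbon but not the fluoromethyl in its place. In a physicochemical assay for lipophilicity, using the shake flask method, in phosphate buffer, measured as octanol-water partition, at pH 7.4 (on this read-out lower numbers stand for lower lipophilicity and higher numbers for higher lipophilicity), compound 3 gives 3.1 and compound 4 gives 3.1, and the same change gives no change at the digits printed from compound 3 to compound 4 (within the scatter), so the large step in binding stands without any step in that read-out, and no measurement at hand accounts for it.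

Open, as far as these compounds go, is whether the step follows the added chain carbon itself or the fluorine carried on it, which a plain ethoxy group, or a longer chain such as 3-fluoropropoxy, would separate. Also open, from the compounds shown here alone, is whether 2-fluoroethoxy costs as much on the core of compound 1.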